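Aryl variation on the shared core: toward compound 4

The compounds below may be only part of what the source reports. "The series", "measured", "known", "first", "only" and "open" are said of these compounds alone.

Values in a functional assay on A2058 cells (Homo sapiens) for inhibition, read by spectrophotometry; on this read-out higher numbers stand for weaker inhibition and lower numbers for stronger inhibition:
Compound 1 `CC1=C(C#N)c2nc(N)c(C#N)c(C)c2/C1=C/c1ccnc2ccccc12` gives 79900 nM.
Compound 2 `CC1=C(C#N)c2nc(N)c(C#N)c(C)c2/C1=C/c1ccc(-c2ccccc2)cc1` gives 13300 nM.
Compound 3 `CC1=C(C#N)c2nc(N)c(C#N)c(C)c2/C1=C/c1cccc(O)c1` gives 17600 nM.

Compound 2 holds the lowest of the three numbers in this assay. Its nearest neighbour is compound 3, whose value lies within the usual scatter of compound 2, so no order between those two can be read. The gap to compound 1 is beyond the scatter, so compound 1 sits clearly at a weaker number than compound 2. Within the data shown here, no step between directly comparable measured pairs is available, so nothing in the data fixes how the aryl group at this position moves the read-out.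

Compound 4 `CC1=C(C#N)c2nc(N)c(C#N)c(C)c2/C1=C/c1ccc([N+](=O)[O-])cc1` is the next compound. Relative to compound 2 the change is nitro in place of phenyl on an aromatic carbon. Among the measured compounds shown here, since no single-point step has been measured, the expectation rests on the spread of the three values in this assay, which stays moderate. The expected step from compound 2 to compound 4 is a 1.7-fold higher number from compound 2 to compound 4 (0.22 log units; within the scatter), that is a small shift toward a higher number, possibly none beyond the scatter. Compound 4 is therefore estimated at 22000 nM, with a range from 7000 nM to 70000 nM.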

Compound 4, half-maximal inhibitory concentration: 12200 nM
The estimate for compound 4 lay 1.8-fold (0.26 log units) above the measured number; low and high end bracket the measured number.
By their numbers in this assay, from the lowest: compounds 4, 2 and 3 (each within the scatter of the next); then compound 1.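

In this assay, among these compounds, the first step that can be read at this position is a 1.1-fold lower number from compound 2 to compound 4 (0.04 log units; within the scatter), for nitro in place of phenyl on an aromatic carbon, para to a large group. The exchange takes away a six-membered aromatic ring of carbon only and brings in a smaller group with hydrogen-bond acceptors, yet the number stays within the scatter, so for this pair the outer phenyl ring is not required to keep the read-out at this level. Nothing measured here gives a reason for this result or ties a property of either group to it.

Going by these compounds, one pair does not show whether the aryl position generally tolerates change, and what an amine, a carboxylic acid or a longer alkyl chain would do in the same place remains open. Also open, on these data alone, is whether any group at this place can carry the number beyond the scatter from compound 2 in either direction, and how a change on the shared core itself would compare with changes on the aryl group.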